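This account rests on a few compounds, and the source may have more. Where it says the series, first, only, none or still open, it means among the compounds named here.

Compound 2 `CC(=O)Nc1ccc(OCc2nnc(SCC(=O)Nc3ccc(S(N)(=O)=O)cc3)n2Cc2ccccc2)cc1` sits at the limit of > 125 ug/mL in this assay, at which 1 of the 2 values shown sits, in a toxicity assay on MT4 cells (Homo sapiens) for cytotoxicity, read by MTT assay, with a stated time of 5 days; on this read-out higher numbers stand for lower toxicity in this test and lower numbers for higher toxicity in this test. In this assay compound 2 gives > 125 ug/mL, a limit of the assay rather than a number. Compound 1 `Cc1ccc(C(C)C)c(OCc2nnc(SCC(=O)Nc3ccc(S(N)(=O)=O)cc3)n2Cc2ccccc2)c1` in this assay gives 13 ug/mL. Among the measured compounds shown here, the only measured step is an at least 9.6-fold higher number from compound 1 to compound 2 (0.98 log units; beyond the scatter). Compound 3 `NS(=O)(=O)c1ccc(NC(=O)CSc2nnc(COc3ccc4ccccc4c3)n2Cc2ccccc2)cc1` differs from compound 2 by naphthalen-2-yl in place of 4-acetamidophenyl on an oxygen on a saturated carbon. Since this change removes the 4-acetamidophenyl whose arrival gave an at least 9.6-fold higher number from compound 1 to compound 2 (0.98 log units; beyond the scatter), the step of an at least 6.2-fold lower number from compound 2 to compound 3 (0.79 log units; beyond the scatter) is expected to run back toward the number of compound 1, a lower value. Compound 3 is estimated at 20 ug/mL, with a range from 7 ug/mL to 125 ug/mL.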

Compound 3, half-maximal cytotoxic concentration: 94.5 ug/mL
The estimate for compound 3 lay 4.7-fold (0.67 log units) below the measured number; the measured number falls inside the stated range.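

In this assay, the higher number at this place, on an oxygen on a saturated carbon, is not tied to 4-acetamidophenyl: with naphthalen-2-yl in place of 2-isopropyl-5-methylphenyl, the result is a 7.3-fold higher number from compound 1 to compound 3 (0.86 log units; beyond the scatter). Compound 2 remains a limit of the assay, not a number: the limit of > 125 ug/mL in this assay, at which 1 of the 3 values shown sits. Read against that limit, the change to naphthalen-2-yl gives an at least 1.3-fold lower number from compound 2 to compound 3 (0.12 log units; that floor lies within the scatter), so no real drop is established.

Still open, going by these compounds, is where a plain phenyl or a 4-carboxyphenyl on this oxygen would fall in this assay. On these data alone, the size of the true gap between the 4-acetamidophenyl and naphthalen-2-yl groups also remains open.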